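A few compounds are considered here, and "the series" means these few. Any claim that something is new, unique, unknown or untested is made for them only; others in the source may bear on it.

The series shares a core built around an acylurea linked to a benzothiazole that carries a sulfonylpropyl chain ending in an amine. In a physicochemical assay for lipophilicity (a higher number here means a more lipophilic compound, a lower number a more polar compound), compound 1 `Cc1cc(C)n(-c2ccc(Cl)c(C(=O)NC(=O)Nc3nc4ccc(S(=O)(=O)CCCN5CCN(C)CC5)cc4s3)c2)n1` gives 2.5. Compound 2 `CCN(CC)CCCS(=O)(=O)c1ccc2nc(NC(=O)NC(=O)c3cc(-n4cccn4)ccc3Cl)sc2c1` gives 2.1 in this assay. Compound 3 `CN1CCN(CCCS(=O)(=O)c2ccc3nc(NC(=O)NC(=O)c4cc5c(ccn5C)cc4Cl)sc3c2)CC1` gives 2.8, the highest of the three numbers; compound 1 lies nearest, a difference that falls within the scatter, while compound 2 lies furthest, a difference that lies beyond the scatter.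

Compound 4 `CN1CCN(CCCS(=O)(=O)c2ccc3nc(NC(=O)NC(=O)c4cc(-n5cccn5)ccc4Cl)sc3c2)CC1` has not yet been measured in this assay. It differs from compound 3 in one place: 2-chloro-5-(1H-pyrazol-1-yl)phenyl in place of 5-chloro-1-methyl-1H-indol-6-yl on a carbonyl carbon. Compound 2 also carries the 2-chloro-5-(1H-pyrazol-1-yl)phenyl group and sits at the lowest of the measured numbers, and compound 1, which shares the terminal amine of compound 4, sits lower than compound 3. Against this background the step from compound 3 to compound 4 is expected to be downward and to reach beyond the scatter, estimated at a number 0.70 log units lower from compound 3 to compound 4 (beyond the scatter). For compound 4 the expected value in this assay is 2.1, with a range from 1.7 to 2.5.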

Compound 4, distribution coefficient: 2
Compound 4: the middle estimate sits 0.10 log units above what was measured, and the stated range covers the measured number.
By their numbers in this assay, from the lowest: compounds 4 and 2 (each within the scatter of the next); then compounds 1 and 3 (each within the scatter of the next).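

In this assay, among these compounds, the exchange of 5-chloro-1-methyl-1H-indol-6-yl for 2-chloro-5-(1H-pyrazol-1-yl)phenyl on a carbonyl carbon gives a number 0.80 log units lower from compound 3 to compound 4 (beyond the scatter) and provides the first single-place comparison at this position, showing that the change there moves the number beyond the scatter while the 4-methylpiperazin-1-yl end stays fixed. The other two comparisons separate the remaining changes: 4-methylpiperazin-1-yl in place of diethylamino on a saturated chain carbon gives a number 0.10 log units lower from compound 2 to compound 4 (within the scatter) and so stays within the scatter, whereas 1H-pyrazol-1-yl in place of 3,5-dimethyl-1H-pyrazol-1-yl on an aromatic carbon gives a number 0.50 log units lower from compound 1 to compound 4 (beyond the scatter) and so lies beyond it. No measurement at hand accounts for the size of any of these steps.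

The compounds shown leave open whether the exchange on the carbonyl carbon would produce a step of similar size with diethylamino at the chain end, and whether a morpholin-4-yl group there would also stay within the scatter. They also leave open how a pyrazole carrying a single methyl group would compare with the unsubstituted and 3,5-dimethyl forms.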